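This account rests on a few compounds, and the source may have more. Where it says the series, first, only, none or still open, it means among the compounds named here.

Measured compounds in an in vitro ADME assay on microsomes from liver (Homo sapiens) for pharmacokinetics, read by LC-MS, with a stated time of 10 min, tested at 1 uM; on this read-out lower numbers stand for slow clearance and higher numbers for fast clearance:
- compound 1 `CN1C[C@H](C(=O)Nc2ccc(C3CC3)cc2)[C@@H](c2ccc(/C=C/C(=O)Nc3ccccc3N)cc2)C1`: 12 mL/min/kg
- compound 2 `CN1C[C@H](C(=O)Nc2cccc(F)c2)[C@@H](c2ccc(/C=C/C(=O)Nc3ccccc3N)cc2)C1`: 6 mL/min/kg
- compound 3 `CN1C[C@H](C(=O)Nc2cccc(Cl)c2)[C@@H](c2ccc(/C=C/C(=O)Nc3ccccc3N)cc2)C1`: 7 mL/min/kg

Compound 3 sits between the other two numbers: a 1.2-fold higher number from compound 2 to compound 3 (0.07 log units; within the scatter), and a 1.7-fold lower number from compound 1 to compound 3 (0.23 log units; within the scatter). All three values lie within the scatter of one another, so no ordering among them can be claimed.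

Compound 4 `Cc1ccc(NC(=O)[C@H]2CN(C)C[C@@H]2c2ccc(/C=C/C(=O)Nc3ccccc3N)cc2)cn1` is not yet measured. It differs from compound 3 in one place: 6-methylpyridin-3-yl in place of 3-chlorophenyl on an amide-type nitrogen.

Among the compounds with values here, the steps that bear on this are the three exchanges of the aryl group on the same amide-type nitrogen: a 2.0-fold lower number from compound 1 to compound 2 (0.30 log units; within the scatter), a 1.7-fold lower number from compound 1 to compound 3 (0.23 log units; within the scatter) and a 1.2-fold higher number from compound 2 to compound 3 (0.07 log units; within the scatter). Within the data shown here, none of them moved this assay beyond the scatter, and none involves a pyridine in place of a phenyl, so the data give no direct precedent for that part of the change. The expectation is therefore that compound 4 stays close to compound 3, with a step that is expected to be a 1.2-fold lower number from compound 3 to compound 4 (0.07 log units; within the scatter), not beyond the scatter. Compound 4 is estimated to give 6 mL/min/kg in this assay, within a range from 3 mL/min/kg to 13 mL/min/kg.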

Compound 4, clearance: 8 mL/min/kg
Compound 4: middle estimate off by 1.3-fold (0.12 log units), on the low side; low and high end bracket the measured number.
By their numbers in this assay, from the lowest: compounds 2, 3, 4 and 1 (each within the scatter of the next).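

Within the data shown here, at this amide-type nitrogen, an aromatic ring with a hetero atom now appears for the first time: in this assay, 6-methylpyridin-3-yl in place of 3-chlorophenyl gives a 1.1-fold higher number from compound 3 to compound 4 (0.06 log units; within the scatter). The exchanges for the other two aryl groups give a 1.3-fold higher number from compound 2 to compound 4 (0.12 log units; within the scatter) and a 1.5-fold lower number from compound 1 to compound 4 (0.18 log units; within the scatter), so all four aryl groups at this position remain within the scatter of one another in this assay, even with a hydrogen-bond acceptor entering on the ring. Nothing shown explains this flat result.

The ring nitrogen and the methyl enter together, so their separate contributions cannot be told apart. Also open, as far as these compounds go, is whether a carboxylic acid or an aminomethyl group on this aryl ring would take this assay beyond the scatter.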